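The compounds below may be only part of what the source reports. "The series", "measured", "known", "first", "only" and "open" are said of these compounds alone.

Working notes on the series. In a functional assay on HL-60 cells (Homo sapiens) for inhibition, read by MTT assay, with a stated time of 72 h (on this read-out lower numbers stand for stronger inhibition and higher numbers for weaker inhibition), compound 1 (`Cc1nc(-c2ccccc2Cl)c(C(=O)N2CCN(c3cccc(Cl)c3)CC2)o1`) gives 132 nM. For the measured compounds named here, compound 3 (`COc1cc(OC)cc(N2CCN(C(=O)c3onc(C)c3-c3ccc(-c4ccco4)cc3)CC2)c1`) gives 191 nM, but no single-place step connects it to the compounds discussed here. Compound 2 (`Cc1ccc(C)c(N2CCN(C(=O)c3oc(C)nc3-c3ccccc3Cl)CC2)c1`) reads > 1000 nM, which is a limit and not a number. That places compound 2 at the limit of > 1000 nM in this assay, at which 1 of the 3 values shown sits.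

Compound 4 (`Cc1ccc(C)c(N2CCN(C(=O)c3oc(C)nc3-c3cccc(F)c3)CC2)c1`) follows from compound 2 through (3-fluorophenyl in place of 2-chlorophenyl on an aromatic carbon). In words, 3-fluorophenyl stands in place of 2-chlorophenyl on an aromatic carbon of the five-membered aromatic ring.

Going by the values given here, only one measured step touches compound 2: an at least 7.5-fold higher number from compound 1 to compound 2 (0.87 log units; beyond the scatter). That step puts 2,5-dimethylphenyl in place of 3-chlorophenyl on an amine nitrogen in a ring, so it concerns a different place in the molecule. The 2,5-dimethylphenyl group is retained in compound 4. Among the compounds with values here, no measured step covers the change on the aromatic carbon, so neither direction is favoured in this assay, and no step beyond the scatter is expected. With compound 2 reported only as a limit, the size of any change also stays poorly defined. The expected change is a step that the limit leaves unreadable from compound 2 to compound 4. For compound 4 the estimated value is 1200 nM, with an expected range from 400 nM to 3500 nM.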

Compound 4, half-maximal inhibitory concentration: 204 nM
Compound 4: the middle estimate sits 5.9-fold (0.77 log units) above what was measured, outside the stated range (below it).
By their numbers in this assay, from the lowest: compounds 1, 3 and 4 (each within the scatter of the next). At a limit, above all of these: compound 2.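

In this assay, the group on this aromatic carbon of the five-membered ring clearly matters with the 2,5-dimethylphenyl group held constant: the change to 3-fluorophenyl from 2-chlorophenyl gives an at least 4.9-fold lower number from compound 2 to compound 4 (0.69 log units; beyond the scatter). Compound 2 is reported only as a limit and not as a number, so the true size of this step stays undefined: the limit of > 1000 nM in this assay, at which 1 of the 4 values shown sits. The 2,5-dimethylphenyl group on the amine nitrogen therefore does not by itself rule out a measured number, since compound 4 carries that group and reads 204 nM.

This single step changes the halogen and its place on the phenyl ring together, so the compounds shown cannot separate the contribution of fluorine for chlorine from that of the shifted substitution, and a plain phenyl group or a phenyl bearing a carboxylic acid at this carbon would help to divide the two. From the compounds shown here alone, it also remains open whether 3-fluorophenyl at this carbon would give a similar step alongside the 3-chlorophenyl group of compound 1 on the amine nitrogen.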